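This account rests on a few compounds, and the source may have more. Where it says the series, first, only, none or still open, it means among the compounds named here.

Measured in a functional assay on HT-29 cells (Homo sapiens) for inhibition, read by MTT assay, with a stated time of 48 h; a higher number here means a weaker inhibitor, a lower number a stronger inhibitor:
- compound 1 `COc1cc(-c2nnc(SC)n2-c2ccc(N(C)C)cc2)cc(OC)c1OC`: > 60000 nM (a limit, not a number)
- compound 2 `COc1cc(-c2nnc(SCc3ccccc3)n2-c2ccc(N(C)C)cc2)cc(OC)c1OC`: > 60000 nM (a limit, not a number)
- compound 3 `COc1cc(-c2nnc(SCC(=O)c3ccccc3)n2-c2ccc(N(C)C)cc2)cc(OC)c1OC`: 45200 nM

Compound 3 is the only one of these with a true number. The other two show (the limit of > 60000 nM in this assay, at which 2 of the 3 values shown sit).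

The next compound, compound 4 `COc1cc(-c2nnc(SCC(=O)c3ccc4ccccc4c3)n2-c2ccc(N(C)C)cc2)cc(OC)c1OC`, keeps everything in compound 3 except one group: naphthalen-2-yl in place of phenyl on a carbonyl carbon.

Three measured steps are nearby. Two of them are an at least 1.3-fold lower number from compound 1 to compound 3 (0.12 log units; that floor lies within the scatter) and an at least 1.3-fold lower number from compound 2 to compound 3 (0.12 log units; that floor lies within the scatter). The third is a step that the two limits leave unreadable from compound 1 to compound 2. None of them alters the group on the carbonyl carbon, so they offer only weak guidance. Given the small gain seen in an at least 1.3-fold lower number from compound 2 to compound 3 (0.12 log units; that floor lies within the scatter), only a modest move toward a lower number is expected, and it may not exceed the scatter. The expected change is a 1.5-fold lower number from compound 3 to compound 4 (0.18 log units; within the scatter). For compound 4 the estimated value is 30000 nM, with an expected range of 10000 nM to 60000 nM.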

Compound 4, half-maximal inhibitory concentration: > 60000 nM
Compound 4: no number, only a limit (the forecaster's own chance of this, stated with the estimate: 25%); at least 2.0-fold (0.30 log units) between middle value and limit.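

In this assay, the first change shown on the carbonyl carbon, naphthalen-2-yl in place of phenyl, gives no sign of a lower number: it produces an at least 1.3-fold higher number from compound 3 to compound 4 (0.12 log units; that floor lies within the scatter). Compound 4 gives > 60000 nM, which is a limit and not a number. Within the data shown here, compound 3 therefore remains the only compound with a true number, and the steps from compound 1 and from compound 2 to compound 4 cannot be read: the limit of > 60000 nM in this assay, at which 3 of the 4 values shown sit.

From the compounds shown here alone, the true size of the step to compound 4 stays open, as its value could lie anywhere on the far side of that limit. Also open, going by these compounds, is whether an amine or a methoxy group on the phenyl of compound 3 would move the number in this assay.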